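Aryl pyrrolidine series: dropping one methoxy group

The source may hold more compounds than are shown below. What is called first, only, known or untested is meant among the compounds shown, and "the series" means these compounds.

Compound 1 `Cc1ccc([C@@]2(CO)NC[C@H](O)[C@H]2O)cc1` and compound 2 `COc1ccc([C@@]2(CO)NC[C@H](O)[C@H]2O)cc1OC` share the same core. In an assay on isolated protein for inhibition of lysosomal alpha-glucosidase (Homo sapiens), tested at 1000 uM (on this read-out higher numbers stand for more inhibition at the one concentration tested (going by the name of the read-out) and lower numbers for less inhibition), compound 1 gives 45.9%, while compound 2 gives 27.1%. Compound 2 stands lowest of the two numbers, and the nearest, compound 1, sits higher by a gap beyond the scatter. Compound 3 `COc1cccc([C@@]2(CO)NC[C@H](O)[C@H]2O)c1` is not yet measured; it differs from compound 2 by hydrogen in place of methoxy on an aromatic carbon. Going by the values given here, no step between measured compounds covers this change. Compound 1, with 45.9%, is the only anchor for a less substituted ring. The expected step is a number 7.9 percentage points higher from compound 2 to compound 3 (within the scatter), upward and modest. Compound 3 is estimated at 35%, between 15% and 55%.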

Compound 3, a percentage reported as inhibition, at one concentration (the size of the read-out at that concentration, not a potency): 46%
For compound 3 the middle estimate is 11 percentage points below the measured one, within the range that was stated.
By their numbers in this assay, from the lowest: compound 2; then compounds 1 and 3 (each within the scatter of the next).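

In this assay hydrogen in place of methoxy, on the aromatic carbon ortho to a methoxy group and para to a group of 9 heavy atoms, gives a number 18.9 percentage points higher from compound 2 to compound 3 (beyond the scatter) and this is the only single-place step shown for the series. The methoxy group at this place is therefore not required for the inhibition read here, and its loss raises the number. Nothing available explains the step.

Going by these compounds, whether an amine or a carboxylic acid on this carbon would move the number up or down remains open. Also open, on these data alone, is whether the remaining methoxy group can be exchanged for hydrogen with a step of similar size.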